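The compounds below may be only part of what the source reports. "The series", "measured", "known", "first", "only" and "open" are said of these compounds alone.

Measured so far in a physicochemical assay for solubility, in phosphate buffer, measured as kinetic solubility, with a stated time of 1 h, at pH 7.4; a lower number here means a less soluble compound, a higher number a more soluble compound:
compound 1 `CCCc1cc(OCC(=O)Nc2cc(C)cc(C)c2)c2cc(OC)ccc2n1`: 12000 nM
compound 2 `COc1ccc2nc(C)cc(OCC(=O)Nc3ccccc3)c2c1`: 63000 nM

For the measured compounds named here, compound 2 holds the higher of the two numbers in this assay; the only other measured compound, compound 1, sits well below it, and the gap between them is beyond the scatter. Going by the values given here, compound 1 and compound 2 differ in more than one place, so no single step between them can be read, and their two values show only that compound 2 is the more soluble of the pair.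

Compound 3 `COc1ccc2nc(C)cc(OCC(=O)Nc3ccc(Cl)c(OC)c3)c2c1` is the next member to be measured in this assay. Against compound 2 the change is 4-chloro-3-methoxyphenyl in place of phenyl on an amide-type nitrogen; the shared core and the ether-linked amide are kept.

Among the compounds with values here, no measured step of this type is available. The expectation for compound 3 in this assay is a modest downward step, a 3.2-fold lower number from compound 2 to compound 3 (0.50 log units; beyond the scatter), since compound 2 at 63000 nM already holds the upper end of the numbers seen. The estimate for compound 3 is 20000 nM, with a range from 6000 nM to 60000 nM.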

Compound 3, solubility: 13000 nM
For compound 3 the middle estimate is 1.5-fold (0.19 log units) above the measured one; the range from low to high includes it.
By their numbers in this assay, from the lowest: compounds 1 and 3 (each within the scatter of the next); then compound 2.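

In this assay the group on the amide-type nitrogen now has a step of its own: 4-chloro-3-methoxyphenyl in place of phenyl gives a 4.8-fold lower number from compound 2 to compound 3 (0.69 log units; beyond the scatter), with the shared core and the ether-linked amide kept. For the compounds shown here, this is the first reading at a single place, as the earlier pair differed in more than one place and could not show whether this position alone moves the number beyond the scatter. The step gives the size of the change but not its origin, and nothing measured here bears on the reason for it.

As far as these compounds go, the change brings in the chlorine and the methoxy together, so their separate shares stay open; 4-chlorophenyl and 3-methoxyphenyl on the same nitrogen would divide the step between them. Also open, from the compounds shown here alone, is how a group of another kind on that ring, such as an amine or a carboxylic acid, would read in this assay, and whether the step holds on a core with a longer chain.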